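Swapping Methyl for Difluorophenyl on a Sulfonamide

A few compounds are considered here, and "the series" means these few. Any claim that something is new, unique, unknown or untested is made for them only; others in the source may bear on it.

In a functional assay on HCT-116 cells (Homo sapiens) for antiproliferative activity, read by sulforhodamine B assay, with a stated time of 72 h (on this read-out lower numbers stand for stronger inhibition and higher numbers for weaker inhibition), compound 2 `COc1ncc(-c2ccc3ncnc(Nc4ccc(OCCO)nc4)c3c2)cc1NS(C)(=O)=O` gives 5360 nM, the highest number of the two measured compounds. For the measured compounds named here, compound 1 `COc1ncc(-c2ccc3ncnc(Nc4cnn(CC(=O)O)c4)c3c2)cc1NS(=O)(=O)c1ccc(F)cc1F` gives 1540 nM, a lower number, yet it differs from compound 2 in two parts of the molecule, so no single step links them. As far as these compounds go, compound 3 `COc1ncc(-c2ccc3ncnc(Nc4ccc(OCCO)nc4)c3c2)cc1NS(=O)(=O)c1ccc(F)cc1F` is untested; it differs from compound 2 by 2,4-difluorophenyl in place of methyl on a sulfonyl sulfur. Compound 3 is expected to move toward lower numbers, by a 2.7-fold lower number from compound 2 to compound 3 (0.43 log units; beyond the scatter), because compound 1 with the same sulfonyl group gives 1540 nM. Compound 3 is estimated at 2000 nM, within 600 nM to 6500 nM.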

Compound 3, half-maximal inhibitory concentration: 2340 nM
Compound 3: the middle estimate sits 1.2-fold (0.07 log units) below what was measured; the range from low to high includes it.
By their numbers in this assay, from the lowest: compounds 1 and 3 (each within the scatter of the next); then compound 2.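

In this assay, for the compounds shown here, 2,4-difluorophenyl in place of methyl on a sulfonyl sulfur gives a 2.3-fold lower number from compound 2 to compound 3 (0.36 log units; beyond the scatter) as a modest step, which isolates this change for the first time. With that sulfonyl group held constant, 6-(2-hydroxyethoxy)pyridin-3-yl in place of 1-(carboxymethyl)-1H-pyrazol-4-yl gives a 1.5-fold higher number from compound 1 to compound 3 (0.18 log units; within the scatter) and so does not separate these two groups in this assay. No supporting measurement explains either step. Whether the fluorine atoms matter remains open, since plain phenyl is not among the compounds shown. As far as these compounds go, how a cyclopropyl group or a longer alkyl chain on the sulfonyl sulfur would compare also remains open.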